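The source may report more compounds than this note shows. Statements on the series, on what has been measured and on what is new or still open speak of the compounds shown alone.

Measured compounds:
compound 1 `CN1CCN(C[C@H]2CN(c3ccc(-n4cc(-c5ccccn5)cn4)c(F)c3)C(=O)O2)CC1`: 1690000 nM
compound 2 `CC(=O)OC[C@H]1CN(c2ccc(-n3cc(-c4ccccn4)cn3)c(F)c2)C(=O)O1`: 373000 nM
compound 3 `CS(=O)(=O)NC[C@H]1CN(c2ccc(-n3cc(-c4ccccn4)cn3)c(F)c2)C(=O)O1`: 2300 nM

In a physicochemical assay for solubility, read by HPLC, with a stated time of 24 h (a higher number here means a more soluble compound, a lower number a less soluble compound), compound 3 gives the lowest of the three numbers: compound 2 sits well above it, and compound 1 higher still. The step to the new compound 4 `CNC(=O)[C@H]1CN(c2ccc(-n3cc(-c4ccccn4)cn3)c(F)c2)C(=O)O1` is methylcarbamoyl in place of (methanesulfonamido)methyl on a saturated ring carbon. Within the data shown here, no measured step swaps these two groups, so the closest guides are the steps that end at compound 3: a 730-fold lower number from compound 1 to compound 3 (2.87 log units; beyond the scatter) and a 160-fold lower number from compound 2 to compound 3 (2.21 log units; beyond the scatter), both large drops into the (methanesulfonamido)methyl compound. Removing that group again, as the step to compound 4 does, therefore points upward, though the incoming methylcarbamoyl is neither an acetoxy nor a 4-methylpiperazin-1-yl group, so how far up cannot be read from a measured step. A rise beyond the scatter is expected for compound 4, a 13-fold higher number from compound 3 to compound 4 (1.12 log units; beyond the scatter). That rise would be expected to place compound 4 between compound 3 and compound 2. Compound 4 is estimated at 30000 nM, with a range from 3000 nM to 300000 nM.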

Compound 4, solubility: 26200 nM
Beside the measured number, compound 4's estimate is 1.1-fold (0.06 log units) above it, within the range that was stated.
By their numbers in this assay, from the lowest: compound 3; then compound 4; then compound 2; then compound 1.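

Both the leaving (methanesulfonamido)methyl and the entering methylcarbamoyl carry one hydrogen-bond donor and no net charge, yet an 11-fold higher number from compound 3 to compound 4 (1.06 log units; beyond the scatter) appears in this assay, so matching those two counts does not make this position give the same number. Compound 4 still stays well under the other two compounds, with a 14-fold lower number from compound 2 to compound 4 (1.15 log units; beyond the scatter) and a 65-fold lower number from compound 1 to compound 4 (1.81 log units; beyond the scatter) marking its distance from them, so all four groups on this saturated ring carbon now stand apart beyond the scatter. Nothing available explains these differences.

Methylcarbamoyl differs from (methanesulfonamido)methyl in more than one feature, so the compounds shown cannot tell whether the sulfonyl part or the chain length matters more. A methylcarbamoyl on a longer chain, or a simple amine or carboxylic acid on this ring carbon, would help separate these features.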